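Changing the Aryl Group on the Piperazine Nitrogen

A few compounds are considered here, and "the series" means these few. Any claim that something is new, unique, unknown or untested is made for them only; others in the source may bear on it.

Measured compounds:
compound 1 `CCC1(CCCCN2CCN(c3cccc(OC)c3)CC2)C(=O)Nc2ccccc21` gives 2.55 nM
compound 2 `CCC1(CCCCN2CCN(c3ccc(OC)cc3)CC2)C(=O)Nc2ccccc21` gives 25.4 nM
compound 3 `CCC1(CCCCN2CCN(c3ccc(F)cc3)CC2)C(=O)Nc2ccccc21` gives 0.43 nM

All three share one core and differ only in the aromatic group on the ring nitrogen. In an assay on CHO cells for displacement of a labelled ligand from 5-hydroxytryptamine receptor 7 (Homo sapiens) (a lower number here means a stronger inhibitor, a higher number a weaker inhibitor), compound 3 stands lowest of the three, and the steps of a 5.9-fold lower number from compound 1 to compound 3 (0.77 log units; beyond the scatter) and a 59-fold lower number from compound 2 to compound 3 (1.77 log units; beyond the scatter) both lie beyond the scatter. Compound 4 `CCC1(CCCCN2CCN(c3ccc(C)c(Cl)c3)CC2)C(=O)Nc2ccccc21` carries the change (3-chloro-4-methylphenyl in place of 4-fluorophenyl on an amine nitrogen in a ring). Among the measured compounds shown here, no measured step places chloro or methyl on this ring, so no direct guide exists. The nearest evidence is a 10-fold higher number from compound 1 to compound 2 (1.00 log units; beyond the scatter) and a 59-fold lower number from compound 2 to compound 3 (1.77 log units; beyond the scatter), which show that this group can shift the number strongly. A modest rise from the very low value of compound 3 is therefore expected. The expected step is a 3.5-fold higher number from compound 3 to compound 4 (0.54 log units; beyond the scatter). Compound 4 is estimated at 1.5 nM, likely between 0.4 nM and 6 nM.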

Compound 4, inhibition constant: 0.66 nM
Compound 4: the middle estimate sits 2.3-fold (0.36 log units) above what was measured; the measured number falls inside the stated range.
By their numbers in this assay, from the lowest: compounds 3 and 4 (each within the scatter of the next); then compound 1; then compound 2.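

In this assay, the step is a 1.5-fold higher number from compound 3 to compound 4 (0.19 log units; within the scatter), so this ring nitrogen can carry an aryl group with two substituents and keep a number as low as that of the 4-fluorophenyl group. Both methoxyphenyl compounds stand clearly apart from the new group, as a 38-fold lower number from compound 2 to compound 4 (1.59 log units; beyond the scatter) and a 3.9-fold lower number from compound 1 to compound 4 (0.59 log units; beyond the scatter) show. Nothing measured here explains these differences.

From the compounds shown here alone, it remains open how chloro alone or methyl alone would compare on this ring. A trifluoromethyl or nitrile group in the same place also remains untested in the compounds shown.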